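The source may report more compounds than this note shows. Statements on the series, on what has been measured and on what is new or still open speak of the compounds shown alone.

Measured compounds:
compound 1 `Cc1nc2c(Br)c(Br)c(Br)c(Br)c2n1CC#N`, 45%;
compound 2 `N#CCCn1cnc2c(Br)c(Br)c(Br)c(Br)c21`, 80%;
compound 3 `Cc1nc2c(Br)c(Br)c(Br)c(Br)c2n1CCCC#N`, 68%.

In a functional assay on CCRF-CEM cells (Homo sapiens) for cytotoxicity, read by MTT assay, with a stated time of 24 h, tested at 10 uM (a higher number here means a weaker effect of the compound at the concentration tested, a lower number a stronger effect), compound 2 gives the highest reading of the three, beyond the scatter from both others. Compound 3 differs from compound 1 by 2-cyanoethyl in place of cyano on a saturated chain carbon bound to an aromatic nitrogen, and this change made a step of a number 23 percentage points higher from compound 1 to compound 3 (beyond the scatter). Compound 4 `N#CCCCCn1cnc2c(Br)c(Br)c(Br)c(Br)c21` has not been measured; it differs from compound 2 by 2-cyanoethyl in place of cyano on a saturated chain carbon, two bonds along the chain from an aromatic nitrogen. The cores of compound 2 and compound 1 are built from the same atoms joined differently, but that difference is not broken down here. The place of the change in compound 4 is not identical to the place of the change from compound 1 to compound 3. The change in compound 4 is therefore the same kind of change, not the same one. Since compound 2 already lies high at 80%, the room upward is small, so a smaller step is expected for compound 4, estimated at a number 8 percentage points higher from compound 2 to compound 4 (within the scatter). Compound 4 is expected to give about 88%, between 72% and 100%.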

Compound 4, a percentage reported as activity, at one concentration (the size of the read-out at that concentration, not a potency): 98%
Compound 4: the middle estimate sits 10 percentage points below what was measured, and the stated range covers the measured number.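

In this assay, 2-cyanoethyl in place of cyano gave a number 18 percentage points higher from compound 2 to compound 4 (beyond the scatter). Set beside the earlier step, the change carried from the core of compound 1 to the core of compound 2 in the same direction and with no size difference that can be told apart: the same change on two cores in this assay, a number 23 percentage points higher (beyond the scatter) from compound 1 to compound 3 and a number 18 percentage points higher (beyond the scatter) from compound 2 to compound 4, 5 percentage points apart, within the scatter of two such steps This rests on two pairs only, with the change at a different place on the chain in each, so it shows agreement on these two cores, not a rule for other cores, and it gives no cause for the higher readings.

The compounds shown leave open whether a longer chain would carry the same step. They also leave open how an amine or a carboxylic acid in place of the nitrile would read.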